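Thiazole Acetic Acids at Prostaglandin D2 Receptor 2: Aryl Swap

The source may hold more compounds than are shown below. What is called first, only, known or untested is meant among the compounds shown, and "the series" means these compounds.

Measured compounds:
- compound 1, `Nc1nc(-c2ccc(Cl)cc2)c(CC(=O)O)s1`: > 100000 nM
- compound 2, `O=C(O)Cc1sc(C(c2ccc(F)cc2)c2ccc(F)cc2)nc1-c1ccco1`: 18 nM
- compound 3, `O=C(O)Cc1sc(C2COc3ccccc3O2)nc1-c1ccc(Cl)cc1`: 500 nM

In an in vitro assay on HEK385-7 cells for displacement of a labelled ligand from prostaglandin D2 receptor 2 (Homo sapiens) (a higher number here means a weaker inhibitor, a lower number a stronger inhibitor), compound 2 gives 18 nM, the lowest of the two numbers shown. Compound 3 gives 500 nM in this assay, a gap above compound 2 that lies beyond the scatter. For compound 1 this assay reports only a limit, > 100000 nM, and no number; this is the case (the limit of > 100000 nM in this assay, at which 1 of the 3 values shown sits).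

Compound 4, `Cc1cc(-c2nc(C(c3ccc(F)cc3)c3ccc(F)cc3)sc2CC(=O)O)ccn1`, has not yet been measured. Relative to compound 2 the change is 2-methylpyridin-4-yl in place of furan-2-yl on an aromatic carbon. Among the measured compounds shown here, no pair of measured compounds differs in this one place, so the size of the step rests on expectation alone. A modest weakening is expected, since the entering group is larger than the leaving one and the other measured variations at the thiazole carbons moved the read-out by more than the scatter. For compound 4 the expected value in this assay is 60 nM, with a range of 12 nM to 400 nM. The step this implies is expected to be a 3.3-fold higher number from compound 2 to compound 4 (0.52 log units; beyond the scatter).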

Compound 4, half-maximal inhibitory concentration: 3.1 nM
Estimate against measurement, compound 4: 19-fold (1.29 log units) above; measured number outside the range, below it.
By their numbers in this assay, from the lowest: compound 4; then compound 2; then compound 3. At a limit, above all of these: compound 1.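

In this assay, putting 2-methylpyridin-4-yl in place of furan-2-yl on the aromatic carbon next to the ring nitrogen gives a 5.8-fold lower number from compound 2 to compound 4 (0.76 log units; beyond the scatter), the first step read at this position. A five-membered aromatic ring is therefore not required here: a six-membered aromatic ring carrying a methyl group is accepted, with a stronger inhibitor as the result. No measured property in the data bears on why the number falls.

The step changes ring size, hetero atom and methyl group at once, and the compounds shown leave open which of these carries it. Also open, from the compounds shown here alone, is how an unsubstituted pyridin-4-yl, or an amine in place of the methyl group on the pyridine ring, would compare with compound 4.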